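Swapping methoxy for methyl on a fatty amide imine

A few compounds are considered here, and "the series" means these few. Any claim that something is new, unique, unknown or untested is made for them only; others in the source may bear on it.

Of the compounds shown here, three sharing one core have been measured so far: compound 1 `CCCCCCCCCCCCCCNC(=O)[C@H](CO)/N=C/c1ccccc1[N+](=O)[O-]`, compound 2 `CCCCCCCCCCCCCCNC(=O)[C@H](CO)/N=C/c1ccccc1OC` and compound 3 `CCCCCCCCCCCCCCNC(=O)[C@H](CO)/N=C/c1ccc(Cl)cc1`. In an ADME assay on HEK293 cells (Homo sapiens) for cytotoxicity (a lower number here means a stronger inhibitor, a higher number a weaker inhibitor), compound 1 gives 82600 nM, compound 2 gives 79200 nM and compound 3 gives 77700 nM. Compound 2 stands second highest of the three, but the gaps are tiny: a 1.0-fold lower number from compound 1 to compound 2 (0.02 log units; within the scatter), a 1.0-fold lower number from compound 2 to compound 3 (0.01 log units; within the scatter) and a 1.1-fold lower number from compound 1 to compound 3 (0.03 log units; within the scatter) all fall within the scatter.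

Compound 4 `CCCCCCCCCCCCCCNC(=O)[C@H](CO)/N=C/c1ccccc1C` differs from compound 2 by methyl in place of methoxy on an aromatic carbon. Among the measured compounds shown here, no measured step matches this exact exchange. The three steps that do exist each replace one aromatic substituent with another, and none of them moved this assay beyond the scatter, so a change of the same kind on the same ring is expected to leave the number where it is.

For compound 4 the expected step is a 1.0-fold lower number from compound 2 to compound 4 (0.00 log units; within the scatter), essentially none beyond the scatter. Compound 4 is therefore estimated at 79000 nM, with a plausible range from 40000 nM to 160000 nM.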

Compound 4, half-maximal inhibitory concentration: 81100 nM
Beside the measured number, compound 4's estimate is 1.0-fold (0.01 log units) below it, and the stated range covers the measured number.
By their numbers in this assay, from the lowest: compounds 3, 2, 4 and 1 (each within the scatter of the next).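

Methyl on this aromatic carbon, ortho to a large group, gives a 1.0-fold higher number from compound 2 to compound 4 (0.01 log units; within the scatter) in this assay, so here the loss of the methoxy oxygen, and with it the hydrogen-bond acceptor, leaves the number within the scatter. The other two new steps, a 1.0-fold higher number from compound 3 to compound 4 (0.02 log units; within the scatter) and a 1.0-fold lower number from compound 1 to compound 4 (0.01 log units; within the scatter), are also within the scatter, which places a plain carbon substituent in the same band as the nitro, methoxy and 4-chlorophenyl compounds. Nothing available here explains why these groups read alike.

Still open, on these data alone, is whether a group of a different kind on the ring, such as an amine or a carboxylic acid, would also stay within this band. The same question applies to a shorter chain in place of the long fatty chain shared by all four compounds.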